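Shortening the hydroxamic acid chain in a urea series

The source may report more compounds than this note shows. Statements on the series, on what has been measured and on what is new or still open speak of the compounds shown alone.

Three compounds that share a urea bridge to a chloro-trifluoromethyl-substituted phenyl ring have been tested in a functional assay on A549 cells (Homo sapiens) for inhibition, read by sulforhodamine B assay, with a stated time of 48 h; on this read-out lower numbers stand for stronger inhibition and higher numbers for weaker inhibition. Compound 1, `O=C(Nc1ccc2c(c1)N(Cc1ccc(C(=O)NO)cc1)CC2)Nc1ccc(Cl)c(C(F)(F)F)c1`, gives 2800 nM. Compound 2, `O=C(Nc1ccc(C(=O)NO)cc1)Nc1ccc(Cl)c(C(F)(F)F)c1`, gives 7200 nM. Compound 3, `O=C(CCCCCCC(=O)Nc1ccc(NC(=O)Nc2ccc(Cl)c(C(F)(F)F)c2)cc1)NO`, gives 9500 nM, the highest of the three numbers. Its nearest neighbour is compound 2, whose number sits within the usual scatter of compound 3, so the two cannot be ranked against each other. Compound 1 stands furthest away, with a number lower than that of compound 3 by more than the scatter.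

Compound 4, `O=C(CCCC(=O)Nc1ccc(NC(=O)Nc2ccc(Cl)c(C(F)(F)F)c2)cc1)NO`, has not yet been measured. It differs from compound 3 in one place: hydroxycarbamoyl in place of 3-(hydroxycarbamoyl)propyl on a saturated chain carbon, three bonds along the chain from a carbonyl carbon. In plain terms the chain that ends in the hydroxamic acid is made shorter, while the rest of the molecule is unchanged.

Among the measured compounds shown here, no measured pair in this set shows what such a shortening does, so the expectation rests on compound 3 alone. The step of a 1.3-fold higher number from compound 3 to compound 4 (0.10 log units; within the scatter) is expected to stay small, most likely within the scatter, with a slight lean toward a higher number. Compound 4 is therefore estimated at 12000 nM, with a plausible range from 5000 nM to 30000 nM.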

Compound 4, half-maximal inhibitory concentration: > 10000 nM
Compound 4 gave a limit, no number; the forecaster's own chance of this, stated with the estimate: 10%; the middle value lies beyond the limit too.
By their numbers in this assay, from the lowest: compound 1; then compounds 2 and 3 (each within the scatter of the next). At a limit, above all of these: compound 4.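

In this assay compound 4 gives > 10000 nM, which is a limit of the assay and not a number. Shortening the chain from 6-(hydroxycarbamoyl)hexyl to 3-(hydroxycarbamoyl)propyl gives an at least 1.0-fold higher number from compound 3 to compound 4 (0.02 log units; that floor lies within the scatter), and placing ((3-(hydroxycarbamoyl)propyl)carbonyl)amino in place of hydroxycarbamoyl on an aromatic carbon gives an at least 1.3-fold higher number from compound 2 to compound 4 (0.14 log units; that floor lies within the scatter). Among the compounds shown here, this chain has now been varied for the first time, and the shorter version shows no sign of a lower number, although neither floor separates compound 4 from the compound it is compared with, and its true distance from them remains unknown, as the reading ends at a limit: the limit of > 10000 nM in this assay, at which 1 of the 4 values shown sits.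

On these data alone, it remains open how chains of intermediate length, such as 4-(hydroxycarbamoyl)butyl or 5-(hydroxycarbamoyl)pentyl, or a chain longer than that of compound 3, would read in this assay. Also open, as far as these compounds go, is what a carboxylic acid or an amine would do in place of the hydroxamic acid at the end of the chain.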